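Triazole-linked chromenone series: benzyl variation and HeLa cytotoxicity

A few compounds are considered here, and "the series" means these few. Any claim that something is new, unique, unknown or untested is made for them only; others in the source may bear on it.

Measured compounds:
Compound 1 `Cc1cccc(Cn2cc(COc3ccc4c(=O)ccoc4c3)nn2)c1` — > 100000 nM in a functional assay on HeLa cells (Homo sapiens) for cytotoxicity, read by MTT assay, with a stated time of 48 h; a lower number here means a stronger inhibitor, a higher number a weaker inhibitor (a limit, not a number)
Compound 2 `O=c1ccoc2cc(OCc3cn(Cc4ccc(Cl)cc4Cl)nn3)ccc12` — 80600 nM in this assay
Compound 3 `O=c1ccoc2cc(OCc3cn(Cc4ccc(F)cc4)nn3)ccc12` — 12000 nM in this assay

Compound 1 reports only a limit, (the limit of > 100000 nM in this assay, at which 1 of the 3 values shown sits). Among the two numbers, compound 3 stands lowest, with compound 2 the nearest, a 6.7-fold lower number from compound 2 to compound 3 (0.83 log units; beyond the scatter). Against compound 1 the step reads an at least 8.3-fold lower number from compound 1 to compound 3 (0.92 log units; beyond the scatter), while an at least 1.2-fold lower number from compound 1 to compound 2 (0.09 log units; that floor lies within the scatter) sits at a floor inside the scatter.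

The next compound, compound 4 `O=c1ccoc2cc(OCc3cn(Cc4ccccc4Br)nn3)ccc12`, is not yet measured. It differs from compound 3 by 2-bromophenyl in place of 4-fluorophenyl on a saturated chain carbon bound to an aromatic nitrogen. For the measured compounds named here, two measured steps bear on it: the move from 3-methylphenyl and from 2,4-dichlorophenyl to 4-fluorophenyl, each lowering the number by a modest or at least modest margin. Going by the values given here, the reverse direction, from 4-fluorophenyl to another substituted phenyl, has so far gone the other way, with compound 2 carrying 2,4-dichlorophenyl as the only halogenated comparison. A higher number than compound 3 is therefore expected, of modest size, with the possibility that only a limit is returned. The expected step is a 3.3-fold higher number from compound 3 to compound 4 (0.52 log units; beyond the scatter). Compound 4 is estimated at 40000 nM, within 12000 nM to 120000 nM.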

Compound 4, half-maximal inhibitory concentration: 14500 nM
Compound 4: middle estimate off by 2.8-fold (0.44 log units), on the high side; low and high end bracket the measured number.
By their numbers in this assay, from the lowest: compounds 3 and 4 (each within the scatter of the next); then compound 2. At a limit, above all of these: compound 1.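

In this assay, for the compounds shown here, the step reads a 1.2-fold higher number from compound 3 to compound 4 (0.08 log units; within the scatter), so 4-fluorophenyl is no longer the only group at this place on a saturated chain carbon bound to an aromatic nitrogen that gives a number in this range, and 2-bromophenyl serves equally well within the scatter. Compound 4 also repeats the separation that compound 3 showed from the other two groups, with a 5.6-fold lower number from compound 2 to compound 4 (0.74 log units; beyond the scatter) and an at least 6.8-fold lower number from compound 1 to compound 4 (0.83 log units; beyond the scatter), though compound 2 goes against any reading that a halogen on the phenyl ring is enough to reach this range. The step from compound 1 is only a floor, as compound 1 gives a limit and not a number: the limit of > 100000 nM in this assay, at which 1 of the 4 values shown sits.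

On these data alone, whether the identity of the halogen or its place on the ring matters stays open, as compound 3 and compound 4 differ in both at once. Also open, as far as these compounds go, is how a phenyl ring carrying an amine or a carboxylic acid, or a longer chain in place of the single saturated carbon, would read in this assay.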